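Trimming the amine chain of compound 1

The compounds below may be only part of what the source reports. "The series", "measured", "known", "first", "only" and "open" are said of these compounds alone.

Measured in a functional assay on HT-29 cells (Homo sapiens) for antiproliferative activity, read by MTT assay, with a stated time of 48 h; on this read-out higher numbers stand for weaker inhibition and lower numbers for stronger inhibition:
- Compound 1 `COc1cc(C(=O)/C=C/c2ccc(OCCCC(=O)NCCCCN(CCCN)CCCCN)cc2)cc(OC)c1OC`: 87200 nM
- Compound 2 `COc1ccc(/C=C/C(=O)c2cc(OC)c(OC)c(OC)c2)cc1OCCCC(=O)NCCCNCCCCNCCN`: > 100000 nM (a limit, not a number)

For the measured compounds named here, compound 1 holds the only true number in this small set, 87200 nM. The result for compound 2, > 100000 nM, is a limit of the measurement and not a number.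

The compound still to be measured is compound 3 `COc1cc(C(=O)/C=C/c2ccc(OCCCC(=O)NCCCNCCCCN)cc2)cc(OC)c1OC`. It keeps the core of compound 1 and differs only in its amine chain: (4-aminobutyl)amino in place of ((4-aminobutyl)(3-aminopropyl)amino)methyl on a saturated chain carbon, three bonds along the chain from an amide-type nitrogen. The group that enters, (4-aminobutyl)amino, is the smaller of the two, and it sits on a saturated chain carbon, three bonds along the chain from an amide-type nitrogen.

Going by the values given here, no two measured compounds differ in one place only, so no measured step shows what such a change does. With compound 1 at 87200 nM, little room is left for a rise in this assay, and nothing measured points to a large gain. The expected change is no larger than the usual scatter: a 1.1-fold lower number from compound 1 to compound 3 (0.04 log units; within the scatter). For compound 3 the estimate is 80000 nM, with an expected range from 35000 nM to 100000 nM.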

Compound 3, half-maximal inhibitory concentration: > 100000 nM
Compound 3: no number, only a limit; the forecaster's own chance of this, stated with the estimate: 35%; middle value at least 1.2-fold (0.09 log units) from the limit.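

Replacing ((4-aminobutyl)(3-aminopropyl)amino)methyl with the smaller (4-aminobutyl)amino on this saturated chain carbon brings no gain in this assay, and the change reads as an at least 1.1-fold higher number from compound 1 to compound 3 (0.05 log units; that floor lies within the scatter). That step is only a floor, since the result for compound 3 is a limit and not a number, so how much higher its true value lies cannot be read. The comparison is therefore weak, because compound 3 sits at the edge of what this read-out reports, as do most of the values in this small set: the limit of > 100000 nM in this assay, at which 2 of the 3 values shown sit.

Compound 1 gives 87200 nM, and the compounds shown leave open whether any group at this place can bring that number much further down, since neither direction of a real change in strength has been seen here. A simple amine, a hydroxyl group or a carboxylic acid in place of (4-aminobutyl)amino, or a longer chain carrying further amines, would test whether this position matters at all for the antiproliferative effect.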